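Swapping One Group on a Shared Core

A few compounds are considered here, and "the series" means these few. Any claim that something is new, unique, unknown or untested is made for them only; others in the source may bear on it.

Compound 1 `CCOC(=O)C1=C(NN=C(C(C)=O)C(C)=O)Nc2[nH]nc(C)c2C1c1ccc(N(C)C)cc1`: 9740 nM
Compound 2 `CCOC(=O)C1=C(N/N=C(/C#N)C(=O)OCC)Nc2[nH]nc(C)c2C1c1ccc(N(C)C)cc1`: 35600 nM

Both values come from a functional assay on MCF7 cells (Homo sapiens) for inhibition, read by MTT assay, with a stated time of 48 h; on this read-out lower numbers stand for stronger inhibition and higher numbers for weaker inhibition. Compound 2, at 35600 nM, holds the higher of the two numbers, which makes it the weaker inhibitor of the pair. Next comes compound 3 `CCOC(=O)C1=C(N/C=N/c2nnc(S(N)(=O)=O)s2)Nc2[nH]nc(C)c2C1c1ccc(N(C)C)cc1`, which keeps the shared core and changes only the group on an amine nitrogen: a group of 11 heavy atoms (3 carbon, 4 nitrogen, 2 oxygen, 2 sulfur; one five-membered aromatic ring with 3 hetero atoms) in place of a group of 9 heavy atoms (5 carbon, 2 nitrogen, 2 oxygen; no ring), on an amine nitrogen.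

Among the compounds with values here, only one measured step bears on this change: a 3.7-fold higher number from compound 1 to compound 2 (0.56 log units; beyond the scatter). That step also swapped a group on an amine nitrogen, and its size is modest. A single step is thin evidence, and the group entering compound 3 is unlike the groups in either measured compound. Compound 1, at 9740 nM, shows that a different group there can give a lower number, so a modest move downward is expected, with little certainty about its direction. The estimated step is a 2.2-fold lower number from compound 2 to compound 3 (0.35 log units; beyond the scatter). For compound 3 the estimated value is 16000 nM, with an expected range from 4000 nM to 50000 nM.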

Compound 3, half-maximal inhibitory concentration: 34500 nM
Compound 3: middle estimate off by 2.2-fold (0.33 log units), on the low side; low and high end bracket the measured number.
By their numbers in this assay, from the lowest: compound 1; then compounds 3 and 2 (each within the scatter of the next).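

The new result shows that a large change in the group on this amine nitrogen need not move the number: in this assay, a group with no ring gives way to one with a five-membered aromatic ring with 3 hetero atoms, and the outcome is a 1.0-fold lower number from compound 2 to compound 3 (0.01 log units; within the scatter), within the usual scatter of repeated measurements. Compound 1 now differs from two unlike groups rather than from a single one, since a 3.5-fold higher number from compound 1 to compound 3 (0.55 log units; beyond the scatter) sits alongside a 3.7-fold higher number from compound 1 to compound 2 (0.56 log units; beyond the scatter), and this makes compound 1 the strongest inhibitor of the three. No measurement shown here accounts for the lower number of compound 1 or for the match between compound 2 and compound 3.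

Going by these compounds, it remains open whether a much smaller group on this nitrogen, such as a methyl, or a group carrying a carboxylic acid or an amine, would give a number lower than that of compound 1 at 9740 nM or would fall with compound 2 and compound 3. On these data alone, all three compounds also share one core and one cell line, so it is unknown whether the same order would hold on a different core or in different cells.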